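Trimming One Trifluoromethyl From a Weak Growth Inhibitor

The source may report more compounds than this note shows. Statements on the series, on what has been measured and on what is new or still open speak of the compounds shown alone.

Compound 1 `O=C(Nc1cccc(-n2cc(-c3ccncc3)c(-c3ccc(Cl)c(O)c3)n2)c1)Nc1cc(C(F)(F)F)cc(C(F)(F)F)c1` is the anchor of this small set. Going by the values given here, in a functional assay on T47D cells (Homo sapiens) for inhibition, read by sulforhodamine B assay, with a stated time of 48 h (a lower number here means a stronger inhibitor of growth, a higher number a weaker inhibitor of growth), compound 1 gives 14000 nM, and this is the only actual number among the three measured compounds. The results for compound 2 and compound 3 are limits of the assay. Compound 2 `COc1cc(-c2nn(-c3cccc(NC(=O)Nc4ccc(Cl)c(C(F)(F)F)c4)c3)cc2-c2ccncc2)ccc1Cl` carries a single trifluoromethyl and a chlorine on its urea-bearing ring, and its result is a limit of the assay: in this assay compound 2 gives > 32500 nM. Compound 3 `COc1cc(-c2nn(-c3cccc(NC(=O)c4ccccc4)c3)cc2-c2ccncc2)ccc1Cl` has a phenyl in place of the (4-chloro-3-(trifluoromethyl)phenyl)amino on the carbonyl carbon, and its result is also a limit of the assay: in this assay compound 3 gives > 100000 nM. Both sit at the limit of > 32500 nM in this assay, at which 1 of the 3 values shown sits, and (the limit of > 100000 nM in this assay, at which 1 of the 3 values shown sits), so the step that the two limits leave unreadable from compound 2 to compound 3 cannot be sized.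

Compound 4 `O=C(Nc1cccc(-n2cc(-c3ccncc3)c(-c3ccc(Cl)c(O)c3)n2)c1)Nc1cccc(C(F)(F)F)c1` differs from compound 1 by hydrogen in place of trifluoromethyl on an aromatic carbon. Among the compounds with values here, none of the measured compounds differ from one another in this way, so no measured step bears on it, and the expectation rests on compound 1 alone. Compound 4 is therefore expected to stay a weak inhibitor, with an estimate of 25000 nM in a range from 8000 nM to 80000 nM. The expected step of a 1.8-fold higher number from compound 1 to compound 4 (0.25 log units; within the scatter) is modest, toward slightly weaker inhibition, and may not exceed the scatter.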

Compound 4, concentration for total growth inhibition: > 32500 nM
Compound 4: only a limit was reported (the forecaster's own chance of this, stated with the estimate: 35%); at least 1.3-fold (0.11 log units) between middle value and limit.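

In this assay, replacing one trifluoromethyl with hydrogen on the aromatic ring gives an at least 2.3-fold higher number from compound 1 to compound 4 (0.36 log units; beyond the scatter), so growth inhibition gets weaker by more than the usual scatter. Going by these compounds alone, this is the first readable step at this position, since the only earlier pair differed elsewhere and its two limits could not be compared. The result for compound 4 is a limit and not a number, so the step gives only a minimum size, and the true loss could be larger: the limit of > 32500 nM in this assay, at which 2 of the 4 values shown sit.

The compounds shown leave open how far compound 4 lies past its limit, and so how much of the modest activity of compound 1 depends on this trifluoromethyl. They also leave open whether a different group at the same place, such as a methyl group or an amine, would hold the activity of compound 1 or lose it as hydrogen does, and so whether trifluoromethyl itself matters or whether any group there would serve.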